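Trimming the urea of compound 1 to a simple amide

The source may report more compounds than this note shows. Statements on the series, on what has been measured and on what is new or still open speak of the compounds shown alone.

Compound 1 `COc1cc(-c2nn(-c3cccc(NC(=O)Nc4ccc(Cl)c(Cl)c4)c3)cc2-c2ccncc2)ccc1Cl` is the reference point here. In a functional assay on NCI-H522 cells (Homo sapiens) for inhibition, read by sulforhodamine B assay, with a stated time of 48 h (on this read-out higher numbers stand for weaker inhibition of growth and lower numbers for stronger inhibition of growth), compound 1 gives 3100 nM, which is the second highest of the three numbers in hand. Its nearest neighbour is compound 3 `O=C(Nc1cccc(-n2cc(-c3ccncc3)c(-c3ccc(Cl)c(O)c3)n2)c1)Nc1cc(C(F)(F)F)cc(C(F)(F)F)c1`, which gives 2510 nM; the two values lie within the usual scatter and cannot be told apart. The furthest is compound 2 `O=C(Nc1cccc(-n2cc(-c3ccncc3)c(-c3ccc(Cl)c(O)c3)n2)c1)Nc1ccc(Cl)c(Cl)c1`, which gives 10600 nM, a step of a 3.4-fold higher number from compound 1 to compound 2 (0.53 log units; beyond the scatter) brought about by hydrogen in place of methyl on an oxygen on an aromatic ring.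

Compound 4 `COc1cc(-c2nn(-c3cccc(NC(=O)c4ccccc4)c3)cc2-c2ccncc2)ccc1Cl` is not yet measured. It differs from compound 1 in one place: phenyl in place of (3,4-dichlorophenyl)amino on a carbonyl carbon. Within the data shown here, the only measured step, from compound 1 to compound 2, sits on the other side of the molecule and does not speak to this change. Among the measured compounds shown here, compounds 2 and 3 carry different groups on the urea end, and their values show a wide spread, which suggests this end of the molecule does matter, though no step between them is tallied. With the urea nitrogen and both chlorines gone, a weaker result is expected for compound 4, roughly a 2.3-fold higher number from compound 1 to compound 4 (0.35 log units; beyond the scatter). The estimate for compound 4 is therefore 7000 nM, with a range from 2500 nM to 20000 nM.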

Compound 4, concentration for total growth inhibition: > 100000 nM
Compound 4: only a limit was reported; the forecaster's own chance of this, stated with the estimate: 10%; at least 14-fold (1.15 log units) between middle value and limit.
By their numbers in this assay, from the lowest: compounds 3 and 1 (each within the scatter of the next); then compound 2. At a limit, above all of these: compound 4.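

In this assay compound 4 gives > 100000 nM, which is a limit of the assay and not a number. Among these compounds, putting phenyl in place of (3,4-dichlorophenyl)amino on a carbonyl carbon gives an at least 32-fold higher number from compound 1 to compound 4 (1.50 log units; beyond the scatter), the only step that can be read at this end of the molecule, and it shows that the group on this carbonyl carbon can matter far more than the change on the other side, which gave a 3.4-fold higher number from compound 1 to compound 2 (0.53 log units; beyond the scatter). The size of the new step is a minimum and not a measured gap: the limit of > 100000 nM in this assay, at which 1 of the 4 values shown sits.

The change takes away the nitrogen with its hydrogen-bond donor and both chlorines in a single move, so the compounds shown cannot tell how much of the loss belongs to the nitrogen and how much to the chlorines. As far as these compounds go, a phenylamino group on the same carbonyl carbon, which keeps the nitrogen without the chlorines, or a 3,4-dichlorophenyl group attached directly to it, which keeps the chlorines without the nitrogen, would pull these two parts apart, and how either would fare remains open.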